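The source may hold more compounds than are shown below. What is called first, only, known or untested is meant among the compounds shown, and "the series" means these compounds.

Working notes on the series. Compound 1 `CCC(C)(C)Cc1c[nH]c(CCc2ccc(-c3csnn3)cc2)n1` gives 109 nM in a functional assay on HEK293 cells for agonist activity at Bombesin receptor subtype-3 (Mus musculus), read by luminescence and calcium flux, with a stated time of 10 min; on this read-out higher numbers stand for an effect only at larger amounts of compound and lower numbers for an effect already at smaller amounts. Compound 2 `CCC(C)(C)Cc1c[nH]c(CCc2ccc(-c3cnccn3)cc2)n1` gives 107 nM in this assay, and compound 3 `CCC(C)(C)Cc1c[nH]c(CCc2ccc(-c3cccc(C#N)n3)cc2)n1` gives 115 nM. Compound 2 holds the smallest of the three numbers, yet the gaps to the others are a 1.0-fold lower number from compound 1 to compound 2 (0.01 log units; within the scatter) and a 1.1-fold higher number from compound 2 to compound 3 (0.03 log units; within the scatter), and a 1.1-fold higher number from compound 1 to compound 3 (0.02 log units; within the scatter) is likewise within the scatter, so none of the three stands apart on these values.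

Compound 4 `CCC(C)(C)Cc1c[nH]c(CCc2ccc(-n3cncn3)cc2)n1` carries the change (1H-1,2,4-triazol-1-yl in place of pyrazin-2-yl on an aromatic carbon). All three measured steps bear on this change, since each replaces the aromatic group on an aromatic carbon of the shared core with another heteroaromatic group, and each of them stayed within the scatter. On that basis no step beyond the scatter is expected in this assay, in either direction, although the entering five-membered ring with three hetero atoms is a somewhat larger departure than the measured swaps. The expected step is a 1.1-fold higher number from compound 2 to compound 4 (0.03 log units; within the scatter). Compound 4 is estimated at 115 nM, with a range from 45 nM to 300 nM.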

Compound 4, half-maximal effective concentration: 121 nM
Compound 4: the middle estimate sits 1.1-fold (0.02 log units) below what was measured; the range from low to high includes it.
By their numbers in this assay, from the lowest: compounds 2, 1, 3 and 4 (each within the scatter of the next).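

The 1H-1,2,4-triazol-1-yl group on this aromatic carbon, para to a large group, extends the set of interchangeable groups in this assay to four, with no step beyond the scatter: a 1.1-fold higher number from compound 2 to compound 4 (0.05 log units; within the scatter), a 1.1-fold higher number from compound 3 to compound 4 (0.02 log units; within the scatter) and a 1.1-fold higher number from compound 1 to compound 4 (0.05 log units; within the scatter). The earlier compounds shown here held only carbon-linked names at this position, so this change adds a different kind of ring name and, with 3 hydrogen-bond acceptors against 2 for pyrazin-2-yl, a different acceptor count without any step beyond the scatter. No measurement is at hand that would explain why these four groups do not separate.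

All four groups are aromatic rings containing hetero atoms, so a carboxylic acid, an amine or an unsubstituted phenyl at this position remains an open case. Whether any such group would produce a step beyond the scatter is not settled by the compounds shown.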